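Methoxy to Methyl on the Fused Ring: Compound 4

A few compounds are considered here, and "the series" means these few. Any claim that something is new, unique, unknown or untested is made for them only; others in the source may bear on it.

Compound 1 `Cc1ccc2nc(Nc3nc(Nc4ccc(S(N)(=O)=O)cc4)ncc3C)sc2c1`: > 50000 nM
Compound 2 `COc1ccc2nc(Nc3nc(Nc4ccc(S(N)(=O)=O)cc4)ncc3F)sc2c1`: > 50000 nM
Compound 3 `COc1ccc2nc(Nc3ccnc(Nc4ccc(S(N)(=O)=O)cc4)n3)sc2c1`: 11000 nM
Compound 4 `Cc1ccc2nc(Nc3ccnc(Nc4ccc(S(N)(=O)=O)cc4)n3)sc2c1`: not yet measured

In a functional assay on MCF7 cells (Homo sapiens) for antiproliferative activity, read by MTT assay, with a stated time of 48 h (on this read-out higher numbers stand for weaker inhibition and lower numbers for stronger inhibition), compound 3 gives 11000 nM. Within the data shown here, that is the only actual number among the three measured compounds. Compound 1 sits at a limit of the assay, > 50000 nM, and is not a number. Compound 2 also sits at a limit, > 50000 nM. Both share (the limit of > 50000 nM in this assay, at which 2 of the 3 values shown sit). Among the measured compounds shown here, the one measured step, an at least 4.5-fold lower number from compound 2 to compound 3 (0.65 log units; beyond the scatter), concerns a different position.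

Compound 4 differs from compound 3 by methyl in place of methoxy on an aromatic carbon. For the measured compounds named here, compound 1 carries the same methyl but also differs elsewhere, so no measured step isolates this change, and compound 1 and compound 2 both sit at the limit, leaving the change unread. With nothing to carry, the expected step from compound 3 to compound 4 is a 1.4-fold higher number from compound 3 to compound 4 (0.13 log units; within the scatter), within the scatter. Compound 4 is therefore expected at 15000 nM, with a range of 5000 nM to 50000 nM.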

Compound 4, half-maximal inhibitory concentration: 5740 nM
Compound 4: middle estimate off by 2.6-fold (0.42 log units), on the high side; measured number inside the range.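

In this assay, methyl in place of methoxy on the six-membered aromatic ring of carbon only gives a 1.9-fold lower number from compound 3 to compound 4 (0.28 log units; within the scatter) so this position takes either group with no readable difference. The new pair also adds a second reading at the other changed aromatic carbon, where hydrogen in place of methyl gives an at least 8.7-fold lower number from compound 1 to compound 4 (0.94 log units; beyond the scatter) and so goes the same way as hydrogen in place of fluoro, which gives an at least 4.5-fold lower number from compound 2 to compound 3 (0.65 log units; beyond the scatter) in the same assay. The true size of both steps remains unknown, because compound 1 and compound 2 each sit at a limit of the assay and not at a number: the limit of > 50000 nM in this assay, at which 2 of the 4 values shown sit.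

The compounds shown leave open whether an amine or a longer chain such as ethoxy on the fused ring would shift the number beyond the scatter. They also leave open how a chloro group would read at the other aromatic carbon.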